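The compounds below may be only part of what the source reports. "The series", "measured", "known", "first", "only" and "open" are said of these compounds alone.

Compound 1 `Cn1c(-c2ccc(NC(=O)CN3CCCC3)cc2)nc2cc(C(F)(F)F)ccc21`: 65000 nM
Compound 2 `CC(=O)Nc1ccc(-c2nc3cc(C(F)(F)F)ccc3n2C)cc1`: 46000 nM

In an ADME assay on MDBK cells (Bos taurus) for cytotoxicity, read by MTT assay, with a stated time of 96 h (a higher number here means that more compound is tolerated, a lower number that less compound is tolerated), compound 2 stands at 46000 nM, while compound 1 stands at 65000 nM; the step of a 1.4-fold lower number from compound 1 to compound 2 (0.15 log units; within the scatter) lies within the scatter, so the two are not separated. Compound 3 `Cn1c(-c2ccc(NC(=O)CN3CCCCC3)cc2)nc2cc(C(F)(F)F)ccc21` differs from compound 2 by piperidin-1-yl in place of hydrogen on a saturated chain carbon bound to a carbonyl carbon. Going by the values given here, the one measured step that bears on this change is a 1.4-fold lower number from compound 1 to compound 2 (0.15 log units; within the scatter), which, read in the reverse direction, adds a saturated nitrogen ring at the same place and moves the number only within the scatter. No step beyond the scatter is therefore expected in this assay. Compound 3 is estimated at 60000 nM, in a range from 30000 nM to 120000 nM, an expected step of a 1.3-fold higher number from compound 2 to compound 3 (0.12 log units; within the scatter).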

Compound 3, half-maximal cytotoxic concentration: 100000 nM
For compound 3 the middle estimate is 1.7-fold (0.22 log units) below the measured one; measured number inside the range.
By their numbers in this assay, from the lowest: compounds 2, 1 and 3 (each within the scatter of the next, the first and the last beyond it).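

In this assay, going by these compounds alone, piperidin-1-yl in place of hydrogen on a saturated chain carbon bound to a carbonyl carbon gives the first step at this position that lies beyond the scatter, though a modest one (a 2.2-fold higher number from compound 2 to compound 3 (0.34 log units; beyond the scatter)). Exchanging the ring itself does not separate the compounds (a 1.5-fold higher number from compound 1 to compound 3 (0.19 log units; within the scatter)), so pyrrolidin-1-yl and piperidin-1-yl cannot be told apart here. No measured evidence accounts for these numbers. The compounds shown leave open how morpholin-4-yl or an open-chain dimethylamino group at this carbon would read in this assay.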